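The compounds below may be only part of what the source reports. "The series", "measured", "known", "first", "only" and "open" are said of these compounds alone.

Working notes on the series. Three compounds carry the same amide-bearing core and differ at the thiocarbonyl end. Compound 1 `CN(C(=S)SCc1ccc(C(=O)Nc2ccccc2N)cc1)c1cccnc1` gives 82.5% in a functional assay on MGC-803 cells (Homo sapiens) for antiproliferative activity, read by CCK-8 assay, with a stated time of 72 h, tested at 8 uM; on this read-out higher numbers stand for a stronger effect at the one concentration tested and lower numbers for a weaker effect. Compound 3 `CC1CCCCN1C(=S)SCc1ccc(C(=O)Nc2ccccc2N)cc1` gives 86.9% in this assay, and the step of a number 4.4 percentage points higher from compound 1 to compound 3 (within the scatter) stays within the scatter. Compound 2 `Nc1ccccc1NC(=O)c1ccc(CSC(=S)N2CCN(c3ccc(F)cc3)CC2)cc1` gives 48.7% in this assay, the lowest of the three numbers; compound 1 lies a number beyond the scatter higher, and compound 3 lies a number beyond the scatter higher still.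

Compound 4 `Nc1ccccc1NC(=O)c1ccc(CSC(=S)N2CCN(c3cnccn3)CC2)cc1` is not yet measured. It differs from compound 2 in one place: pyrazin-2-yl in place of 4-fluorophenyl on an amine nitrogen in a ring. Going by the values given here, no measured step touches this place. Among the compounds with values here, the one step recorded, from compound 1 to compound 3, alters the group on the thiocarbonyl carbon and not the group on the amine nitrogen in a ring, so it gives no direct guide. Within the data shown here, what is known is that compound 2, the only measured compound bearing a six-membered non-aromatic ring with 2 nitrogen at this position, sits well below compounds 1 and 3. Among the measured compounds shown here, with no step bearing on the change, no direction beyond the scatter is expected, and the step of a number 1.3 percentage points higher from compound 2 to compound 4 (within the scatter) is estimated to stay within it. Compound 4 is therefore expected to give about 50% in this assay, with a range from 30% to 70%.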

Compound 4, a percentage reported as inhibition, at one concentration (the size of the read-out at that concentration, not a potency): 80.5%
The estimate for compound 4 lay 30.5 percentage points below the measured number; measured number outside the range, above it.
By their numbers in this assay, from the lowest: compound 2; then compounds 4, 1 and 3 (each within the scatter of the next).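

In this assay the group on the amine nitrogen in a ring of the six-membered non-aromatic ring with 2 nitrogen proves to matter: pyrazin-2-yl in place of 4-fluorophenyl gives a number 31.8 percentage points higher from compound 2 to compound 4 (beyond the scatter) in a single exchange. Going by these compounds alone, the low number of compound 2 is thus not a feature of that ring alone, since the read-out moves with the ring kept and only this one group changed. The entering group differs from the leaving one in its ring atoms, in its hydrogen-bond acceptors and in the loss of fluorine, but no measurement at hand explains the step, and which of these differences carries it stays unassigned.

From the compounds shown here alone, whether the number follows the ring nitrogens or the loss of fluorine stays open, and a plain phenyl or a pyridin-2-yl on the same amine nitrogen would help to separate the two. Also open, going by these compounds, is whether a methyl or an acetyl group in this place, with no aromatic ring at all, would keep the read-out in this assay near that of compound 4.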